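The source may hold more compounds than are shown below. What is called first, only, known or untested is meant among the compounds shown, and "the series" means these compounds.

Compound 3 `Cc1cc(C)c(NS(C)(=O)=O)c(C)c1NC(=O)c1sccc1S(=O)(=O)Nc1onc(C)c1Cl` gives < 10000 ug/mL in a physicochemical assay for solubility, in phosphate buffer, at pH 7.4 (a higher number here means a more soluble compound, a lower number a less soluble compound), which is a limit and not a number: the limit of < 10000 ug/mL in this assay, at which 1 of the 3 values shown sits. Compound 1 `Cc1cc(C)c(NC(=O)c2sccc2S(=O)(=O)Nc2onc(C)c2Cl)c(C)c1` gives 23000 ug/mL, and compound 2 `Cc1cc(C)c(N(C)C)c(C)c1NC(=O)c1sccc1S(=O)(=O)Nc1onc(C)c1Cl` gives 50000 ug/mL. Compound 4 `Cc1cc(C)c(NC(=O)c2sccc2S(=O)(=O)Nc2onc(C)c2Cl)c(C)c1O` has hydroxy in place of methanesulfonamido on an aromatic carbon. The closest measured step is an at least 2.3-fold lower number from compound 1 to compound 3 (0.36 log units; beyond the scatter), which the loss of methanesulfonamido is expected to reverse at least in part. Also relevant are an at least 5.0-fold lower number from compound 2 to compound 3 (0.69 log units; beyond the scatter) and a 2.2-fold higher number from compound 1 to compound 2 (0.34 log units; beyond the scatter), the second showing that a substituent at this place can raise the number modestly. In this assay, a modest rise is therefore expected: an at least 2.2-fold higher number from compound 3 to compound 4 (0.34 log units; beyond the scatter). Compound 4 is estimated at 22000 ug/mL, with an expected range of 10000 ug/mL to 50000 ug/mL.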

Compound 4, solubility: 83000 ug/mL
Compound 4: middle estimate off by 3.8-fold (0.58 log units), on the low side, and the stated range ends below it.
By their numbers in this assay, from the lowest: compound 1; then compounds 2 and 4 (each within the scatter of the next). At a limit, below all of these: compound 3.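

Against hydrogen, hydroxy on this aromatic carbon gives a 3.6-fold higher number from compound 1 to compound 4 (0.56 log units; beyond the scatter) in this assay and shows that a small group here can move the number clearly upward. Against dimethylamino it gives a 1.7-fold higher number from compound 2 to compound 4 (0.22 log units; within the scatter) and cannot be told apart from that group, while against methanesulfonamido it gives an at least 8.3-fold higher number from compound 3 to compound 4 (0.91 log units; beyond the scatter) as the widest step at this place. That step starts from a limit for compound 3: the limit of < 10000 ug/mL in this assay, at which 1 of the 4 values shown sits.

As far as these compounds go, whether a primary amine, methoxy or a carboxylic acid here would match hydroxy remains open. So does whether the hydroxy step holds with other groups on the shared core.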